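A few compounds are considered here, and "the series" means these few. Any claim that something is new, unique, unknown or untested is made for them only; others in the source may bear on it.

In a functional assay on A549 cells (Homo sapiens) for antiproliferative activity, read by MTT assay, with a stated time of 48 h (on this read-out lower numbers stand for stronger inhibition and higher numbers for weaker inhibition), compound 1 `O=C(/C=C/c1ccc(O)c(O)c1)N1CCN(c2ccccc2F)CC1` gives 1.43 ug/mL, while compound 2 `O=C(/C=C/c1ccc(O)c(O)c1)N1CCN(c2ccc(F)cc2)CC1` gives 1.25 ug/mL. Going by the values given here, these two values lie within the scatter of each other, so compound 1 cannot be separated from the only other compound measured so far. Compound 3 `O=C(/C=C/c1ccc(O)c(O)c1)N1CCN(c2ccccc2Cl)CC1` has yet to be measured, and it differs from compound 1 at a single place: chloro in place of fluoro on an aromatic carbon. This is chloro in place of fluoro on an aromatic carbon, ortho to a large group, so that 2-fluorophenyl becomes 2-chlorophenyl. Among the compounds with values here, only one measured step offers any guidance, and only indirectly: a 1.1-fold lower number from compound 1 to compound 2 (0.06 log units; within the scatter). That step exchanges 2-fluorophenyl for 4-fluorophenyl and stays within the scatter. Within the data shown here, no measured compound carries chloro, so the data give no direct reading of this exchange and no firm direction. No step beyond the scatter is therefore expected in this assay. The expected change is a 1.1-fold lower number from compound 1 to compound 3 (0.04 log units; within the scatter), an estimate that stays within the scatter. For compound 3 the estimated value is 1.3 ug/mL, with an expected range of 0.7 ug/mL to 2.5 ug/mL.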

Compound 3, half-maximal inhibitory concentration: 1.44 ug/mL
For compound 3 the middle estimate is 1.1-fold (0.04 log units) below the measured one; measured number inside the range.
By their numbers in this assay, from the lowest: compounds 2, 1 and 3 (each within the scatter of the next).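

In this assay, going by these compounds alone, the step for chloro in place of fluoro on an aromatic carbon, ortho to a large group, is a 1.0-fold higher number from compound 1 to compound 3 (0.00 log units; within the scatter) and gives the first direct reading of this exchange: at this place compound 3 cannot be separated from compound 1. The second new step is a 1.2-fold higher number from compound 2 to compound 3 (0.06 log units; within the scatter) and shows that 2-chlorophenyl on the amine nitrogen in a ring also cannot be separated from the 4-fluorophenyl of compound 2, so the three compounds now shown, which carry either fluoro or chloro on this ring, all read alike in this assay. Nothing is available here that could explain this lack of separation.

The compounds shown leave open whether bromo, methyl or methoxy in the same place would also stay within the scatter of compound 1. They also leave open whether a plain phenyl, with no halogen on the ring at all, would read the same, and so whether fluoro or chloro contributes anything to the values seen here.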